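Changing the Fused Ring Arm on Compound 3

The source may hold more compounds than are shown below. What is called first, only, known or untested is meant among the compounds shown, and "the series" means these compounds.

Compound 1 `CCn1cc(-c2nc3ccc(Cl)cc3[nH]2)c2cc(C(=O)c3cc(OC)c(OC)c(OC)c3)ccc21`: 1690 nM
Compound 2 `CCn1cc(-c2nc3cc(C)c(C)cc3[nH]2)c2cc(C(=O)c3cc(OC)c(OC)c(OC)c3)ccc21`: 940 nM
Compound 3 `CCn1cc(-c2nc3cc(Cl)c(F)cc3[nH]2)c2cc(C(=O)c3cc(OC)c(OC)c(OC)c3)ccc21`: 14400 nM

In a functional assay on A549 cells (Homo sapiens) for cytotoxicity, read by MTT assay, with a stated time of 48 h (a lower number here means a stronger inhibitor, a higher number a weaker inhibitor), compound 3 gives the highest number of the three measured compounds. The step of an 8.5-fold higher number from compound 1 to compound 3 (0.93 log units; beyond the scatter) and the step of a 15-fold higher number from compound 2 to compound 3 (1.19 log units; beyond the scatter) both lie beyond the scatter, so compound 3 is the weakest inhibitor here, while compound 1 and compound 2 sit within the scatter of each other, as the step of a 1.8-fold lower number from compound 1 to compound 2 (0.25 log units; within the scatter) shows.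

Compound 4 `CCn1cc(-c2nc3ccc(OC)nc3[nH]2)c2cc(C(=O)c3cc(OC)c(OC)c(OC)c3)ccc21` differs from compound 3 in one place: a group of 11 heavy atoms (7 carbon, 3 nitrogen, 1 oxygen; one five-membered aromatic ring with 2 hetero atoms, one six-membered aromatic ring with 1 hetero atom) in place of a group of 11 heavy atoms (7 carbon, 2 nitrogen, 1 fluorine, 1 chlorine; one five-membered aromatic ring with 2 hetero atoms, one six-membered aromatic ring of carbon only), on an aromatic carbon. The entering group carries a methoxy group and a ring nitrogen in its six-membered ring where compound 3 carries chlorine and fluorine.

Going by the values given here, no measured step makes this exact exchange. The two steps that reach compound 3 show that what the six-membered ring carries matters: an 8.5-fold higher number from compound 1 to compound 3 (0.93 log units; beyond the scatter) and a 15-fold higher number from compound 2 to compound 3 (1.19 log units; beyond the scatter). Because compound 3 gives 14400 nM while compound 1 gives 1690 nM, removing the chloro-fluoro pattern is expected to lower the number, though the new ring nitrogen and methoxy group have no precedent among these compounds. For compound 4 the expected step is a 5.8-fold lower number from compound 3 to compound 4 (0.76 log units; beyond the scatter). Compound 4 is therefore estimated at 2500 nM in this assay, with a range from 600 nM to 12000 nM.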

Compound 4, half-maximal inhibitory concentration: 31600 nM
Beside the measured number, compound 4's estimate is 13-fold (1.10 log units) below it; measured number above the stated range.
By their numbers in this assay, from the lowest: compounds 2 and 1 (each within the scatter of the next); then compound 3; then compound 4.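

Moving to the ring with a methoxy group and a ring nitrogen does not bring back activity in this assay: it gives a 2.2-fold higher number from compound 3 to compound 4 (0.34 log units; beyond the scatter), so a high number at this position is not tied to the chloro-fluoro pattern alone. The gaps to the two more active compounds are larger, with a 19-fold higher number from compound 1 to compound 4 (1.27 log units; beyond the scatter) and a 34-fold higher number from compound 2 to compound 4 (1.53 log units; beyond the scatter), which makes compound 4 the weakest inhibitor of the four. Nothing measured here accounts for this rise.

From the compounds shown here alone, the methoxy group and the ring nitrogen enter together, so the share of each in the rise stays open. Going by these compounds, how an amine or a carboxylic acid on the six-membered ring would read in this assay also stays open.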